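Cytotoxicity notes on a shared-core series

The compounds below may be only part of what the source reports. "The series", "measured", "known", "first", "only" and "open" are said of these compounds alone.

Measured so far in an ADME assay on MT4 cells (Homo sapiens) for cytotoxicity, read by MTT assay; a lower number here means that less compound is tolerated, a higher number that more compound is tolerated; each value is an assay limit, not a number:
compound 1 `COc1cccc(F)c1CNC(=O)c1[nH]c2ccc(Cl)cc2c1S(=O)(=O)c1cc(C)cc(C)c1`: > 49900 nM
compound 2 `Cc1cc(C)cc(S(=O)(=O)c2c(C(=O)NCC(=O)NCc3ccco3)[nH]c3ccc(Cl)cc23)c1`: > 50000 nM
compound 3 `Cc1cc(C)cc(S(=O)(=O)c2c(C(=O)NC(c3ccc(Cl)cc3)C3CC3)[nH]c3ccc(Cl)cc23)c1`: > 47300 nM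

Compound 1 stands only at a limit in this assay, namely (the limit of > 49900 nM in this assay, at which 1 of the 3 values shown sits). Within the data shown here, the other two values are likewise limits, the limit of > 47300 nM in this assay, at which 1 of the 3 values shown sits, and (the limit of > 50000 nM in this assay, at which 1 of the 3 values shown sits), so no compound can be placed above or below another.

The next compound, compound 4 `Cc1cc(C)cc(S(=O)(=O)c2c(C(=O)NCC(=O)NCc3ccncn3)[nH]c3ccc(Cl)cc23)c1`, changes compound 1 as follows: ((pyrimidin-4-yl)methyl)carbamoyl in place of 2-fluoro-6-methoxyphenyl on a saturated chain carbon bound to an amide-type nitrogen.

The closest measured step is a step that the two limits leave unreadable from compound 1 to compound 2, where a ((furan-2-yl)methyl)carbamoyl group enters at the same place. The steps a step that the two limits leave unreadable from compound 1 to compound 3 and a step that the two limits leave unreadable from compound 2 to compound 3 are equally unreadable, both ends sitting at limits. Nothing in these three steps points to any change in this assay beyond the scatter, and the shared core has stayed at a limit throughout.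

Compound 4 is therefore expected to sit at the limit again, estimated at 50000 nM, within 20000 nM to 100000 nM. The expected step that the limit leaves unreadable from compound 1 to compound 4 is essentially none.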

Compound 4, half-maximal cytotoxic concentration: > 48800 nM
Compound 4: a limit, no number; the forecaster's own chance of this, stated with the estimate: 85%; the middle value is on the limit's open side.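

In this assay compound 4 gives > 48800 nM, which is a limit. Its steps from compound 1, compound 2 and compound 3 cannot be read, as every end sits at a limit. The compounds shown leave open where the half-maximal cytotoxic concentration of any of the four lies.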